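Removing the bromo group: notes on compounds 2 and 3

The source may report more compounds than this note shows. Statements on the series, on what has been measured and on what is new or still open speak of the compounds shown alone.

Measured so far:
Compound 1, `COc1ccc(/C=C/C(=O)NNC(=O)c2ccc3c(c2)OCCO3)cc1`: 930 nM
Compound 2, `O=C(/C=C/c1ccc(Br)cc1)NNC(=O)c1ccc2c(c1)OCCO2`: 2330 nM

Within the data shown here, in a functional assay on cells (Cancer cell lines, Homo sapiens) for inhibition, read by MTT assay, with a stated time of 48 h (on this read-out higher numbers stand for weaker inhibition and lower numbers for stronger inhibition), compound 2 gives the highest of the two numbers; its only neighbour is compound 1, and the two are separated by a 2.5-fold higher number from compound 1 to compound 2 (0.40 log units; beyond the scatter), beyond the scatter.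

Compound 3, `O=C(/C=C/c1ccccc1)NNC(=O)c1ccc2c(c1)OCCO2`, has not been measured. Relative to compound 2 the change is hydrogen in place of bromo on an aromatic carbon; cut one bond further out, it reads 4-bromophenyl to phenyl. Among the measured compounds shown here, the single measured step, a 2.5-fold higher number from compound 1 to compound 2 (0.40 log units; beyond the scatter), exchanges one substituent for another at that aromatic carbon rather than removing one, so it bears on this step only loosely. For the measured compounds named here, with that step as the only guide, and no measured compound lacking a substituent there, a step of modest size is expected, most likely toward a lower number, but the direction is not secure. Compound 3 is therefore estimated at 1700 nM, within 700 nM to 4500 nM. The expected step is a 1.4-fold lower number from compound 2 to compound 3 (0.14 log units; within the scatter).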

Compound 3, half-maximal inhibitory concentration: 550 nM
Beside the measured number, compound 3's estimate is 3.1-fold (0.49 log units) above it, and the stated range ends above it.
By their numbers in this assay, from the lowest: compounds 3 and 1 (each within the scatter of the next); then compound 2.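

In this assay, taking the bromo group off this aromatic carbon, para to a large group, gives a 4.2-fold lower number from compound 2 to compound 3 (0.63 log units; beyond the scatter), so the position does not need a substituent for this read-out and bromo is the group that stands apart. Hydrogen and methoxy do not separate, with a 1.7-fold lower number from compound 1 to compound 3 (0.23 log units; within the scatter), a relation that the earlier bromo and methoxy pair alone could not show. Nothing measured here accounts for either step.

As far as these compounds go, it remains open whether the step out of bromo is particular to that atom or also holds for chloro or fluoro. From the compounds shown here alone, it is equally open whether an amine or a carboxylic acid at this carbon would fall with hydrogen and methoxy or with bromo.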